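Fluoro for Chloro on the Benzyl Arm of Compound 2

The compounds below may be only part of what the source reports. "The series", "measured", "known", "first", "only" and "open" are said of these compounds alone.

Of the compounds shown here, two have so far been measured in a functional assay on Ramos cells (Homo sapiens) for inhibition, read by MTT assay, with a stated time of 2 days; on this read-out lower numbers stand for stronger inhibition and higher numbers for weaker inhibition. Compound 1 `O=C1N=C(Nc2ccc(F)c(Cl)c2)S/C1=C\c1ccc(-c2ccc(C(=O)O)c(O)c2)o1` gives 3100 nM in this assay. Compound 2 `O=C1/C(=C/c2ccc(-c3cc(C(F)(F)F)ccc3Cl)o2)SC(=S)N1Cc1ccc(Cl)cc1` gives 3800 nM, the higher of the two numbers, though its gap to compound 1 lies within the scatter, so the two cannot be ordered. Compound 3 `O=C1/C(=C/c2ccc(-c3cc(C(F)(F)F)ccc3Cl)o2)SC(=S)N1Cc1ccc(F)cc1` has not been measured. It differs from compound 2 in one place: fluoro in place of chloro on an aromatic carbon, the 4-chlorobenzyl becoming a 4-fluorobenzyl. Among the measured compounds shown here, no measured pair shows this exchange, so nothing in the data sets its size. The step is expected to be small, a 1.2-fold higher number from compound 2 to compound 3 (0.07 log units; within the scatter), and not clearly beyond the scatter in either direction. Compound 3 is therefore estimated at 4500 nM, with a range from 1500 nM to 13000 nM.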

Compound 3, half-maximal inhibitory concentration: 4100 nM
The estimate for compound 3 lay 1.1-fold (0.04 log units) above the measured number; the range from low to high includes it.
By their numbers in this assay, from the lowest: compounds 1, 2 and 3 (each within the scatter of the next).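

In this assay, among the compounds shown here, the pair of compound 2 and compound 3 gives the only reading so far of a change in one place: fluoro in place of chloro on the benzyl arm yields a 1.1-fold higher number from compound 2 to compound 3 (0.03 log units; within the scatter). The 4-chlorobenzyl and the 4-fluorobenzyl therefore cannot be told apart on this read-out, so this position accepts either halogen without a change beyond the scatter. The data shown offer no measurement that would explain this result.

The compounds shown leave open whether this position is as indifferent to a group of another kind, such as an amine, a carboxylic acid or a methoxy group, as it is to these two halogens. They also leave open whether the same exchange would behave alike on a different part of the molecule, such as the chloro on the furan-linked phenyl ring.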